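A Fluoro-to-Methyl Swap on a Pyrimidine Nucleoside Core

The source may report more compounds than this note shows. Statements on the series, on what has been measured and on what is new or still open speak of the compounds shown alone.

Within the data shown here, compound 1 `C#C[C@@]1(O)[C@@H](CO)O[C@@H](n2cc(F)c(=O)[nH]c2=O)[C@@H]1O` shows 2500 nM in a functional assay on L1210 cells (Mus musculus) for inhibition (on this read-out lower numbers stand for stronger inhibition and higher numbers for weaker inhibition), the highest of the two numbers known, while compound 2 `C#C[C@]1(O)[C@@H](CO)O[C@H](n2cc(F)c(N)nc2=O)[C@@H]1O` gives 530 nM in this assay. Compound 3 `C#C[C@@]1(O)[C@@H](CO)O[C@@H](n2cc(C)c(=O)[nH]c2=O)[C@@H]1O` carries the change methyl in place of fluoro on an aromatic carbon relative to compound 1, with nothing else altered. Among the measured compounds shown here, no measured pair shows this exact swap, so the size of the step is uncertain. The author expects weaker inhibition, a step of a 4.0-fold higher number from compound 1 to compound 3 (0.60 log units; beyond the scatter) beyond the usual scatter. For compound 3 the estimate in this assay is 10000 nM, with a range from 2000 nM to 50000 nM.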

Compound 3, half-maximal inhibitory concentration: > 300000 nM
Compound 3: only a limit was reported; the forecaster's own chance of this, stated with the estimate: 25%; middle value at least 30-fold (1.47 log units) from the limit.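

The earlier compounds shown here held no pair that isolated this position, and this one does: methyl in place of fluoro on this aromatic carbon, a swap of one heavy atom for one, gives an at least 120-fold higher number from compound 1 to compound 3 (2.07 log units; beyond the scatter) in this assay. The position therefore tolerates this change poorly on the core of compound 1. The value for compound 3 is a limit and not a number, so the step has only a lower bound: the limit of > 300000 nM in this assay, at which 1 of the 3 values shown sits.

From the compounds shown here alone, whether chloro, an amine or a longer chain on this carbon would keep inhibition stays open. So does whether the same swap would act alike on the core of compound 2.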